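The compounds below may be only part of what the source reports. "The series", "measured", "known", "first", "only" and "open" are said of these compounds alone.

Going by the values given here, compound 2 `COc1cc2ncnc(NCc3cccc(NC(=O)Nc4ccc(C(C)(C)C)cc4)c3)c2cc1OC` holds the only number in a functional assay on HepG2 cells (Homo sapiens) for antiproliferative activity, read by MTT assay (a higher number here means a weaker inhibitor, a lower number a stronger inhibitor), giving 6850 nM. Compound 1 `COc1cc2ncnc(NCc3cccc(NC(=O)Nc4ccc(C)cc4)c3)c2cc1OC` in this assay reaches only a limit, > 50000 nM. Between them stands an at least 7.2-fold lower number from compound 1 to compound 2 (0.86 log units; beyond the scatter), a step that rests on (the limit of > 50000 nM in this assay, at which 1 of the 2 values shown sits). Compound 3 `COc1cc2ncnc(NCc3cccc(NC(=O)Nc4ccc(Cl)cc4)c3)c2cc1OC` differs from compound 2 by chloro in place of tert-butyl on an aromatic carbon, on an aromatic carbon of a six-membered aromatic ring of carbon only, para to a large group. The measured step came from enlarging this group; shrinking it back is expected to push the number the other way. Compound 3 is therefore estimated at 20000 nM in this assay, between 6000 nM and 60000 nM. The expected step is a 2.9-fold higher number from compound 2 to compound 3 (0.47 log units; beyond the scatter).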

Compound 3, half-maximal inhibitory concentration: > 50000 nM
Compound 3: a limit, no number; the forecaster's own chance of this, stated with the estimate: 35%; middle value at least 2.5-fold (0.39 log units) away from the limit.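

In this assay, chloro in place of tert-butyl gives an at least 7.2-fold higher number from compound 2 to compound 3 (0.86 log units; beyond the scatter), so of the three groups shown at this aromatic carbon, only tert-butyl yields a number. Compound 3 reaches only a limit, > 50000 nM. The step from compound 1 to compound 3 cannot be read, so methyl and chloro cannot be ordered, and the reading for this position rests on a limit: the limit of > 50000 nM in this assay, at which 2 of the 3 values shown sit.

From the compounds shown here alone, what isopropyl, cyclohexyl or a morpholine on this carbon would give remains open.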